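Adding Chloro to Compound 2: What Compound 3 Might Show

The compounds below may be only part of what the source reports. "The series", "measured", "known", "first", "only" and "open" are said of these compounds alone.

Within the data shown here, compound 2 `Fc1cccc(Cn2nnc3c(Br)cccc32)c1` stands lowest of the two numbers so far in an ADME assay on microsomes from liver (Homo sapiens) for metabolic stability, tested at 2.5 uM (a lower number here means slower removal, a higher number faster removal of the compound), giving 1.8 mL/min/g; compound 1 `Brc1cccc2c1nnn2Cc1ccccc1` gives 4.7 mL/min/g. Among the measured compounds shown here, the single measured step, a 2.6-fold lower number from compound 1 to compound 2 (0.42 log units; beyond the scatter), came from fluoro in place of hydrogen on an aromatic carbon. Compound 3 `Fc1cc(Cn2nnc3c(Br)cccc32)ccc1Cl` differs from compound 2 by chloro in place of hydrogen on an aromatic carbon. No measured step involves chloro, so nothing shown bears directly on this change, and compound 3 is expected to shift no further than the scatter allows, an expected step of a 1.1-fold higher number from compound 2 to compound 3 (0.05 log units; within the scatter). Compound 3 is therefore estimated at 2 mL/min/g, within a range from 0.9 mL/min/g to 4.5 mL/min/g.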

Compound 3, intrinsic clearance in a liver preparation (reported as CLH), per the amount of preparation that the assay uses: 0.4 mL/min/g
For compound 3 the middle estimate is 5.0-fold (0.70 log units) above the measured one, and the stated range ends above it.
By their numbers in this assay, from the lowest: compound 3; then compound 2; then compound 1.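

In this assay, chloro in place of hydrogen, ortho to a fluoro group and para to a large group, brings a 4.5-fold lower number from compound 2 to compound 3 (0.65 log units; beyond the scatter). This shows that this position responds to substitution and that a second halogen can lower the number further once fluoro is present, with no compound shown going against that direction. Nothing at hand accounts for the size of this step.

Going by these compounds, whether the step belongs to chloro itself or to any group at this position remains open, and a methyl group or a nitrile there would separate the two. Also open, on these data alone, is whether chloro acts the same way without the fluoro group.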